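From a Free Hydroxy to a Carboxymethoxy Group

A few compounds are considered here, and "the series" means these few. Any claim that something is new, unique, unknown or untested is made for them only; others in the source may bear on it.

Compound 1, `COc1ccc(/C(=N/O)c2cccc3ccccc23)c(OC)c1OC`, was tested in a functional assay on MCF7 cells (Homo sapiens) for inhibition, read by sulforhodamine B assay, with a stated time of 48 h; on this read-out higher numbers stand for weaker inhibition and lower numbers for stronger inhibition. In this assay compound 1 gives only a limit, > 20000 nM, and no number. Two companions sit in the same position. Compound 2, `C=CCC(O)(c1ccc(OC)c(OC)c1OC)c1cccc2ccccc12`, gives in this assay a limit of > 20000 nM. Compound 3, `C=CCOC(c1ccc(OC)c(OC)c1OC)c1cccc2ccccc12`, likewise gives in this assay a limit of > 20000 nM. All three values therefore share one feature, (the limit of > 20000 nM in this assay, at which 3 of the 3 values shown sit), so compound 1 stands at the edge of what this assay can report rather than at a measured point.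

The unmeasured compound 4, `COc1ccc(/C(=N/OCC(=O)O)c2cccc3ccccc23)c(OC)c1OC`, differs from compound 1 in one place: carboxymethyl in place of hydrogen on an oxygen. Read one bond further out, the change is hydroxy to carboxymethoxy.

With every shown value resting on a limit, no measured step exists from which a direction could be taken. Compound 4 is expected to give about 25000 nM, between 8000 nM and 80000 nM, in this assay. The step that the limit leaves unreadable from compound 1 to compound 4 is thus estimated to be none beyond the scatter, and the most likely outcome remains a limit rather than a number.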

Compound 4, half-maximal inhibitory concentration: > 20000 nM
Compound 4: only a limit was reported; the forecaster's own chance of this, stated with the estimate: 70%; the middle value is on the limit's open side.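

Compound 1 and compound 4 both rest on a limit rather than a number in this assay, so no step can be read between them: the limit of > 20000 nM in this assay, at which 4 of the 4 values shown sit.

The compounds shown leave open whether carboxymethyl in place of hydrogen on an oxygen alters inhibition at all.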